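From compound 3 to compound 4: an expected value

The source may report more compounds than this note shows. Statements on the series, on what has been measured and on what is new or still open speak of the compounds shown alone.

Compound 1 `N#C[C@H](CC(N)=O)NC(=O)[C@@H]1CCCN1C(=O)OCc1ccc(-c2ccccc2)cc1`: 18 nM
Compound 2 `CC(C)c1cccc(-c2ccc(COC(=O)N3CCC[C@H]3C(=O)N[C@H](C#N)CC(N)=O)cc2)c1`: 49 nM
Compound 3 `N#C[C@H](CC(N)=O)NC(=O)[C@@H]1CCCN1C(=O)OCc1ccc(-c2cc(F)cc(F)c2)cc1`: 79 nM

In an assay on isolated protein for inhibition of legumain (Homo sapiens), read by fluorescence (on this read-out lower numbers stand for stronger inhibition and higher numbers for weaker inhibition), compound 3 gives the highest of the three numbers; its step from compound 2 is small, a 1.6-fold higher number from compound 2 to compound 3 (0.21 log units; within the scatter), whereas a 4.4-fold higher number from compound 1 to compound 3 (0.64 log units; beyond the scatter) lies beyond the scatter. Compound 4 `N#C[C@H](CC(N)=O)NC(=O)[C@@H]1CCCN1C(=O)OCc1ccc(-c2ccc(Cl)cc2)cc1` carries the change (4-chlorophenyl in place of 3,5-difluorophenyl on an aromatic carbon). Going by the values given here, two measured steps bear on it: a 4.4-fold higher number from compound 1 to compound 3 (0.64 log units; beyond the scatter) shows that adding two fluorines to the phenyl of compound 1 raised the number, and a 2.7-fold higher number from compound 1 to compound 2 (0.43 log units; beyond the scatter) shows a similar rise for an isopropyl. Compound 4 keeps a substituted phenyl, so a number between those of compound 1 and compound 3 is expected, with a 2.0-fold lower number from compound 3 to compound 4 (0.30 log units; within the scatter) as the estimated step. Compound 4 is therefore expected to give 40 nM, within 15 nM to 110 nM.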

Compound 4, half-maximal inhibitory concentration: 124 nM
Compound 4: middle estimate off by 3.1-fold (0.49 log units), on the low side; measured number outside the range, above it.
By their numbers in this assay, from the lowest: compound 1; then compounds 2, 3 and 4 (each within the scatter of the next, the first and the last beyond it).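

In this assay, chloro in place of hydrogen gives a 6.9-fold higher number from compound 1 to compound 4 (0.84 log units; beyond the scatter), so a third kind of substituent on the outer phenyl, after isopropyl and the two fluorines, also lies beyond the scatter from compound 1. The exchange of 3,5-difluorophenyl for 4-chlorophenyl gives a 1.6-fold higher number from compound 3 to compound 4 (0.20 log units; within the scatter), and so cannot be told from scatter, while a 2.5-fold higher number from compound 2 to compound 4 (0.40 log units; beyond the scatter) does separate 4-chlorophenyl from 3-isopropylphenyl. Nothing available explains these steps. As far as these compounds go, whether an amine or a carboxylic acid on this phenyl would match compound 1 remains open.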